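Swapping 3-chlorophenyl for 4-methoxyphenyl in a cytotoxic pair

The source may hold more compounds than are shown below. What is called first, only, known or untested is meant among the compounds shown, and "the series" means these compounds.

In a functional assay on MCF7 cells (Homo sapiens) for cytotoxicity, read by MTT assay, with a stated time of 24 h (on this read-out higher numbers stand for weaker inhibition and lower numbers for stronger inhibition), compound 1 (`CCNc1cc(-c2ccc(NC(=O)Nc3ccc(C)cc3)cc2C)ccn1`) gives 9210 nM and compound 2 (`CCNc1cc(-c2ccc(NC(=O)Nc3cccc(Cl)c3)cc2C)ccn1`) gives 4180 nM as its value. Compound 2 therefore holds the lower of the two numbers and is the stronger inhibitor of this pair. The next compound to be measured is compound 3 (`CCNc1cc(-c2ccc(NC(=O)Nc3ccc(OC)cc3)cc2C)ccn1`), and the change leading to it (4-methoxyphenyl in place of 3-chlorophenyl on an amide-type nitrogen) places 4-methoxyphenyl in place of 3-chlorophenyl on an amide-type nitrogen.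

Going by the values given here, only one measured step bears on this change: a 2.2-fold lower number from compound 1 to compound 2 (0.34 log units; beyond the scatter) is modest and also concerns the group on that nitrogen. It replaced 4-methylphenyl with 3-chlorophenyl, and the incoming 4-methoxyphenyl has a name closer to the group of compound 1 than to that of compound 2. With a single step as a guide, this comparison is weak. A move back towards the number of compound 1 is expected, at about the size of that measured step. In this assay the expected step is a 2.0-fold higher number from compound 2 to compound 3 (0.31 log units; beyond the scatter) and it points to a higher number. The estimated value for compound 3 is 8500 nM within an expected range from 3800 nM to 19000 nM for now.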

Compound 3, half-maximal inhibitory concentration: 9950 nM
Beside the measured number, compound 3's estimate is 1.2-fold (0.07 log units) below it, within the range that was stated.
By their numbers in this assay, from the lowest: compound 2; then compounds 1 and 3 (each within the scatter of the next).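

In this assay, the 4-methoxyphenyl group on the amide-type nitrogen does not keep the lower number that 3-chlorophenyl brought (a 2.4-fold higher number from compound 2 to compound 3 (0.38 log units; beyond the scatter)), so the gain seen with compound 2 is not shared by every replacement of the 4-methylphenyl group of compound 1. The change of methoxy for methyl on an aromatic carbon leaves compound 3 and compound 1 indistinguishable (a 1.1-fold higher number from compound 1 to compound 3 (0.03 log units; within the scatter)), which makes compound 2 the only one of the three set apart on this read-out, and the added oxygen, with its one hydrogen-bond acceptor, brings no measurable difference from compound 1. No measurement at hand speaks to what lies behind these numbers.

Compound 2 differs from the other two both in its substituent and in where that substituent sits, so the compounds shown cannot say whether its lower number goes with the chlorine or with the arrangement in 3-chlorophenyl. A 4-chlorophenyl or a 3-methoxyphenyl group on the same nitrogen would separate the two, and an aminophenyl or a carboxyphenyl group would extend the comparison to other kinds of substituent.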